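Nitro substitution transferred from one fused core to another

The source may report more compounds than this note shows. Statements on the series, on what has been measured and on what is new or still open speak of the compounds shown alone.

Compound 1 `CCn1cc(-c2nc3ccccc3o2)c(=O)c2cc(F)c(N3CCNCC3)nc21` and compound 2 `CCn1cc(-c2nc3ccccc3s2)c(=O)c2cc(F)c(N3CCNCC3)cc21` share most of their structure, but the difference between the two cores is not broken down here. In a functional assay on Bel-7402 cells (Homo sapiens) for cytotoxicity, read by MTT assay, with a stated time of 48 h (on this read-out lower numbers stand for stronger inhibition and higher numbers for weaker inhibition), compound 1 gives 16800 nM and compound 2 gives 24300 nM, numbers that lie within the scatter of each other. Compound 3 `CCn1cc(-c2nc3ccc([N+](=O)[O-])cc3o2)c(=O)c2cc(F)c(N3CCNCC3)nc21` carries nitro in place of hydrogen on an aromatic carbon and gives 3000 nM, so that a 5.6-fold lower number from compound 1 to compound 3 (0.75 log units; beyond the scatter). Compound 4 `CCn1cc(-c2nc3ccc([N+](=O)[O-])cc3s2)c(=O)c2cc(F)c(N3CCNCC3)cc21` bears the same change on the core of compound 2, namely (nitro in place of hydrogen on an aromatic carbon), and is yet to be measured. He expects for compound 4 a step of a 4.9-fold lower number from compound 2 to compound 4 (0.69 log units; beyond the scatter), close to the earlier one, because a 5.6-fold lower number from compound 1 to compound 3 (0.75 log units; beyond the scatter) and that same change is repeated in an otherwise near-identical setting. On that basis compound 4 is estimated at 5000 nM, in a range from 1500 nM to 16000 nM, in this assay.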

Compound 4, half-maximal inhibitory concentration: 1800 nM
For compound 4 the middle estimate is 2.8-fold (0.44 log units) above the measured one, within the range that was stated.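

Nitro in place of hydrogen on an aromatic carbon again lowers the number in this assay, with a 14-fold lower number from compound 2 to compound 4 (1.13 log units; beyond the scatter). The two steps point the same way and cannot be told apart in size: the same change on two cores in this assay, a 5.6-fold lower number (0.75 log units; beyond the scatter) from compound 1 to compound 3 and a 14-fold lower number (1.13 log units; beyond the scatter) from compound 2 to compound 4, 2.4-fold (0.38 log units) apart, within the scatter of two such steps This shows that the change carried over between these two cores, but it rests on a single pair of steps and does not show why the number falls or that the same would happen on any other core.

The compounds shown leave open whether an amine or a carboxylic acid on that same aromatic carbon would give a step of similar size. They also leave open how the nitro step would behave on a third core.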